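A few compounds are considered here, and "the series" means these few. Any claim that something is new, unique, unknown or untested is made for them only; others in the source may bear on it.

Compound 1 `C=C(Br)C(=O)Nc1cccc(-c2cn3nc(-c4cccc(OC)c4)sc3n2)c1`, compound 3 `C=C(Br)C(=O)Nc1cccc(-c2cn3nc(-c4ccc(OC)c(OC)c4)sc3n2)c1`, compound 2 `COc1cccc(-c2nn3cc(-c4cccc(N)c4)nc3s2)c1` and the not yet measured compound 4 `Nc1cccc(-c2cn3nc(-c4ccccc4)sc3n2)c1` are close relatives. In a functional assay on HeLa cells (Homo sapiens) for inhibition, read by cell counting, with a stated time of 4 days (a higher number here means a weaker inhibitor, a lower number a stronger inhibitor), compound 3 gives 610 nM, compound 1 gives 1100 nM and compound 2 gives 230000 nM. From compound 3 to compound 1 the change is hydrogen in place of methoxy on an aromatic carbon, and it made the step of a 1.8-fold higher number from compound 3 to compound 1 (0.26 log units; within the scatter). A far larger move is seen in a 210-fold higher number from compound 1 to compound 2 (2.32 log units; beyond the scatter), where hydrogen takes the place of (1-bromoethenyl)carbonyl on a nitrogen on an aromatic ring. The difference between the cores of compound 2 and compound 3 is not broken down here. From compound 2 to compound 4 the change is hydrogen in place of methoxy on an aromatic carbon. This is the same kind of change as from compound 3 to compound 1, yet the surroundings differ: there the hydrogen enters ortho to a methoxy group and para to a large group, here meta to a large group. The step of a 1.5-fold higher number from compound 2 to compound 4 (0.18 log units; within the scatter) is expected to be small, because a 1.8-fold higher number from compound 3 to compound 1 (0.26 log units; within the scatter) stayed within the scatter. Compound 4 is therefore expected to give about 350000 nM in this assay, with a range from 120000 nM to 1000000 nM.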

Compound 4, half-maximal inhibitory concentration: 26000 nM
Compound 4: middle estimate off by 13-fold (1.13 log units), on the high side; measured number outside the range, below it.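

The same swap of hydrogen for methoxy does not behave alike across these two pairs in this assay: the same change on two cores in this assay, a 1.8-fold higher number (0.26 log units; within the scatter) from compound 3 to compound 1 and an 8.8-fold lower number (0.95 log units; beyond the scatter) from compound 2 to compound 4, 16-fold (1.20 log units) apart, beyond the scatter of two such steps. Here the change gives an 8.8-fold lower number from compound 2 to compound 4 (0.95 log units; beyond the scatter), so a step that stayed within the scatter in one pair gave no safe forecast for the other. Among the compounds shown here, these are only two pairs, and they differ in the group on the nitrogen as well as in what else the ring carries, so they do not show which of those differences matters, why the steps part ways, or whether any rule holds beyond these four compounds.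

The compounds shown leave open how the same swap behaves when the (1-bromoethenyl)carbonyl group stays on the nitrogen and the ring that loses the methoxy is left with no other group. Also open, as far as these compounds go, is how a fluorine atom, a hydroxy group or a longer ether such as ethoxy would compare with methoxy and hydrogen at that place.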